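A few compounds are considered here, and "the series" means these few. Any claim that something is new, unique, unknown or untested is made for them only; others in the source may bear on it.

Measured compounds:
- compound 1, `Cc1cc(Nc2cc(-c3ccccc3)[nH]n2)n2ncnc2n1`: 21700 nM
- compound 2, `Cc1cc(Nc2cc(-c3ccccc3)[nH]n2)n2nc(SCc3cccc(Br)c3)nc2n1`: 4820 nM
- compound 3, `Cc1cc(Nc2cc(-c3ccc(F)cc3)[nH]n2)n2nc(SCc3ccc(Br)cc3)nc2n1`: 2210 nM

These three compounds share a core and were tested in a functional assay on MGC-803 cells (Homo sapiens) for inhibition, read by MTT assay, with a stated time of 72 h; on this read-out higher numbers stand for weaker inhibition and lower numbers for stronger inhibition. Compound 3 gives the lowest number of the three, with compound 2 the nearest and compound 1 the furthest from it. The one step shown between two measured compounds that differ in a single place is a 4.5-fold lower number from compound 1 to compound 2 (0.65 log units; beyond the scatter), where a (3-bromobenzyl)sulfanyl group replaces a hydrogen on an aromatic carbon.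

Compound 4, `Cc1cc(Nc2cc(-c3ccccc3)[nH]n2)n2nc(SCc3ccc(Br)cc3)nc2n1`, is not yet measured. It differs from compound 3 by hydrogen in place of fluoro on an aromatic carbon, that is, a 4-fluorophenyl becomes a phenyl. Within the data shown here, none of the measured steps touches this position, so no direct guide exists for the size of such a change; the only measured step concerns a different part of the molecule. With nothing to point in either direction, the step is expected to stay within the scatter, and a 1.4-fold higher number from compound 3 to compound 4 (0.13 log units; within the scatter) is the estimated change. Compound 4 is therefore expected to give about 3000 nM in this assay, between 1200 nM and 8000 nM.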

Compound 4, half-maximal inhibitory concentration: 1110 nM
For compound 4 the middle estimate is 2.7-fold (0.43 log units) above the measured one; measured number outside the range, below it.
By their numbers in this assay, from the lowest: compounds 4 and 3 (each within the scatter of the next); then compound 2; then compound 1.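

In this assay, taking the fluoro off the 4-fluorophenyl to leave a phenyl gives a step that stays within the scatter (a 2.0-fold lower number from compound 3 to compound 4 (0.30 log units; within the scatter)), so the two compounds cannot be told apart at this position. The bromine on the benzyl group counts for more, as 4-bromophenyl in place of 3-bromophenyl gives a step beyond the scatter (a 4.3-fold lower number from compound 2 to compound 4 (0.64 log units; beyond the scatter)), and the whole (4-bromobenzyl)sulfanyl group in place of hydrogen gives a large one (a 20-fold lower number from compound 1 to compound 4 (1.29 log units; beyond the scatter)). Nothing available explains the size of any of these steps.

The compounds shown leave open whether a larger group on this ring, such as a methoxy, an amine or a carboxylic acid, would shift the number beyond the scatter. They also leave open what a chloro would do in place of the bromo on the benzyl group.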